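Extending a methyl to ethoxymethyl: from compound 2 to compound 3

The source may hold more compounds than are shown below. What is called first, only, known or untested is meant among the compounds shown, and "the series" means these compounds.

Compound 1, `CCc1nn2c(-c3c(C)cc(C)cc3OC)cccc2c1N(CC1CCOCC1)CC1CC1`: 22 nM
Compound 2, `CCc1nn2c(-c3c(OC)cc(C)cc3OC)cccc2c1N(CC1CCOCC1)CC1CC1`: 22 nM

Of the compounds shown here, two sharing one core have been measured in an assay on HEK293 cells for displacement of a labelled ligand from corticotropin-releasing factor receptor 1 (Homo sapiens), read by scintillation counting, with a stated time of 2 h; on this read-out lower numbers stand for stronger inhibition and higher numbers for weaker inhibition. Among the compounds with values here, compound 1 gives 22 nM, and compound 2 gives 22 nM, so compound 2 stands level with compound 1; the only measured step, no change at the digits printed from compound 1 to compound 2 (within the scatter), swapped one group on an aromatic carbon and left the read-out unchanged within the scatter.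

Compound 3, `CCOCc1cc(OC)c(-c2cccc3c(N(CC4CCOCC4)CC4CC4)c(CC)nn23)c(OC)c1`, differs from compound 2 by ethoxy in place of hydrogen on a saturated chain carbon bound to an aromatic carbon. Within the data shown here, no measured step touches this position, and the one step that exists, no change at the digits printed from compound 1 to compound 2 (within the scatter), concerned a different part of the molecule, so it offers only weak guidance. The shared core is kept intact, which argues for a modest outcome. Compound 3 is therefore expected to give about 30 nM, with a likely range from 10 nM to 90 nM. This expected step, a 1.4-fold higher number from compound 2 to compound 3 (0.13 log units; within the scatter), is estimated to stay within or just beyond the scatter.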

Compound 3, half-maximal inhibitory concentration: 49 nM
The estimate for compound 3 lay 1.6-fold (0.21 log units) below the measured number; the measured number falls inside the stated range.
By their numbers in this assay, from the lowest: compounds 1 and 2 (each within the scatter of the next); then compound 3.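

Extending the methyl to ethoxymethyl on this saturated chain carbon bound to an aromatic carbon moved the read-out in this assay, giving a 2.2-fold higher number from compound 2 to compound 3 (0.35 log units; beyond the scatter). This position therefore responds to change, if only modestly, and the added ethoxy still leaves measurable inhibition, whereas the earlier swap at a different place gave no change at the digits printed from compound 1 to compound 2 (within the scatter). Nothing measured on these compounds explains the rise in the number.

A single step cannot show whether the rise follows the greater length of the new group or the oxygen it carries, and a plain butyl chain, which has the same length without the oxygen, would help to separate the two. Also open, going by these compounds, is how an amine or a carboxylic acid on this chain would read in this assay.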